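The compounds below may be only part of what the source reports. "The series", "measured", "known", "first", "only" and "open" are said of these compounds alone.

Compound 1 `COc1cccc(/C=C/c2ccccc2O)c1` and compound 2 `COc1ccc(/C=C/c2cccc(O)c2)cc1` share the same atoms joined differently; how their two cores differ is not broken down here. In an ADME assay on HEK293 cells (Homo sapiens) for inhibition, read by MTT assay, with a stated time of 2 days (a lower number here means a stronger inhibitor, a higher number a weaker inhibitor), compound 1 gives 20 ug/mL, and compound 2 gives 24 ug/mL, two numbers that lie within the usual scatter of each other. Compound 3 `COc1cccc(/C=C/c2ccccc2N)c1` carries amino in place of hydroxy on an aromatic carbon, and in this assay compound 3 gives 0.5 ug/mL, so that a 40-fold lower number from compound 1 to compound 3 (1.60 log units; beyond the scatter). Compound 4 `COc1ccc(/C=C/c2cccc(N)c2)cc1` carries amino in place of hydroxy on an aromatic carbon. In compound 4 the group sits meta to a large group; in compound 3 it sits ortho to a large group. This is the same kind of change, not the same change. Resting on the step from compound 1 to compound 3, a 40-fold lower number from compound 1 to compound 3 (1.60 log units; beyond the scatter), the expected step is a 24-fold lower number from compound 2 to compound 4 (1.38 log units; beyond the scatter). Compound 4 is therefore estimated at 1 ug/mL, between 0.3 ug/mL and 4 ug/mL.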

Compound 4, half-maximal inhibitory concentration: 11 ug/mL
Beside the measured number, compound 4's estimate is 11-fold (1.04 log units) below it; measured number above the stated range.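

In this assay, putting amino in place of hydroxy on an aromatic carbon again lowers the number, giving a 2.2-fold lower number from compound 2 to compound 4 (0.34 log units; beyond the scatter). The direction of the change carries across these two pairs, but its size does not: the same change on two cores in this assay, a 40-fold lower number (1.60 log units; beyond the scatter) from compound 1 to compound 3 and a 2.2-fold lower number (0.34 log units; beyond the scatter) from compound 2 to compound 4, 18-fold (1.26 log units) apart, beyond the scatter of two such steps The two pairs do not show whether this gap comes from where the group sits or from some other difference between the cores, and they say nothing about any further core.

The compounds shown leave open how a methylamino group, an acetamide or a carboxylic acid would behave at these places. They also leave open whether a methoxy group in place of hydroxy would follow amino on either core.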